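The source may report more compounds than this note shows. Statements on the series, on what has been measured and on what is new or still open speak of the compounds shown alone.

Measured so far in a functional assay on MCF7 cells (Homo sapiens) for cytotoxicity, read by sulforhodamine B assay, with a stated time of 48 h; a lower number here means a stronger inhibitor of growth, a higher number a weaker inhibitor of growth:
- compound 1, `Cc1nn(-c2ccccc2)c(Oc2ccc(-c3nc4cc([N+](=O)[O-])ccc4[nH]3)cc2)c1/C=N/Nc1ccccc1`: 12300 nM
- compound 2, `Cc1nn(-c2ccccc2)c(Oc2ccc(-c3nc4cc([N+](=O)[O-])ccc4[nH]3)cc2)c1/C=N/NC(N)=O`: 13800 nM

For the measured compounds named here, compound 2 is one of only two measured members, and its number in this assay sits alongside that of compound 1: the step of a 1.1-fold higher number from compound 1 to compound 2 (0.05 log units; within the scatter) is within the scatter, so the two are not distinguishable on these data.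

Compound 3 is `Cc1nn(-c2ccccc2)c(Oc2ccc(-c3nc4cc(C(N)=O)ccc4[nH]3)cc2)c1/C=N/NC(N)=O`. It differs from compound 2 by carbamoyl in place of nitro on an aromatic carbon. Going by the values given here, this is a different place from the one varied between compound 1 and compound 2, where the change was on an amine nitrogen at the other end of the shared core; that step, a 1.1-fold higher number from compound 1 to compound 2 (0.05 log units; within the scatter), therefore does not bear on the change to compound 3. Among the compounds with values here, no measured pair alters the substituent on the fused ring, so there is no step from which the size or direction of the effect of replacing nitro by carbamoyl can be read. With nothing to point either way, the expectation for compound 3 in this assay is a number close to that of compound 2, with a wide range: the estimated step is a 1.1-fold higher number from compound 2 to compound 3 (0.04 log units; within the scatter). Compound 3 is thus expected at about 15000 nM, between 5000 nM and 45000 nM.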

Compound 3, concentration for 50% growth inhibition: 6500 nM
For compound 3 the middle estimate is 2.3-fold (0.36 log units) above the measured one, within the range that was stated.
By their numbers in this assay, from the lowest: compounds 3, 1 and 2 (each within the scatter of the next, the first and the last beyond it).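

In this assay, for the compounds shown here, the substituent on the fused ring turns out to be a place where the number moves: carbamoyl in place of nitro on an aromatic carbon gives a 2.1-fold lower number from compound 2 to compound 3 (0.33 log units; beyond the scatter), a modest step but one beyond the scatter, whereas the only earlier step, at the amine nitrogen, gave a 1.1-fold higher number from compound 1 to compound 2 (0.05 log units; within the scatter). Nitro and carbamoyl match in heavy-atom count and neither carries a net charge, while carbamoyl brings a hydrogen-bond donor that nitro lacks, but a single pair cannot tie the step to that difference. No measurement offers an explanation for this step.

From the compounds shown here alone, the effect of the 5-carbamoyl-1H-benzimidazol-2-yl group rests on one pair, so it remains open whether the same step would appear with phenyl in place of carbamoyl on the amine nitrogen. Going by these compounds, it also remains open how a carboxylic acid, an amine or a nitrile on the same aromatic carbon would compare with carbamoyl and nitro in this assay.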